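Moving the Thiophene Attachment and Adding a Formyl Group

This account rests on a few compounds, and the source may have more. Where it says the series, first, only, none or still open, it means among the compounds named here.

Three compounds built on a shared core carrying a chloro-substituted pyridine and a spiro lactam have been measured in a functional assay on MV4-11 cells (Homo sapiens) for inhibition, read by resazurin assay, with a stated time of 72 h; on this read-out lower numbers stand for stronger inhibition of growth and higher numbers for weaker inhibition of growth. Compound 2 `Cc1csc(-c2cncc(Cl)c2N2CCC3(CCNC3=O)CC2)c1` gives 650 nM. Compound 1 `CCOCOCc1ccc(-c2cncc(Cl)c2N2CCC3(CCNC3=O)CC2)o1` gives 2970 nM, and compound 3 `O=C1NCCC12CCN(c1c(Cl)cncc1-c1ccc(CN3CCCCC3)s1)CC2` gives 4010 nM. Compound 2 therefore stands lowest of the three numbers, and both of its neighbours sit beyond the usual scatter, so it is the most potent of the measured set in this assay.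

Compound 4 `O=Cc1cscc1-c1cncc(Cl)c1N1CCC2(CCNC2=O)CC1` has not yet been measured. It differs from compound 2 in one place: 4-formylthiophen-3-yl in place of 4-methylthiophen-2-yl on an aromatic carbon. Among the measured compounds shown here, no step between two measured compounds matches this change, so its effect can only be guessed. The two weaker compounds, compound 1 and compound 3, each carry a larger substituted five-membered ring at this position than compound 2 does, which hints that departures from the small 4-methylthiophen-2-yl group cost activity here.

On that basis compound 4 is expected to be somewhat weaker than compound 2, with an estimated step of a 2.3-fold higher number from compound 2 to compound 4 (0.36 log units; beyond the scatter) in this assay, a moderate loss rather than a large one. The estimated value for compound 4 in this assay is 1500 nM, with a likely range from 450 nM to 5000 nM.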

Compound 4, concentration for 50% growth inhibition: 27100 nM
The estimate for compound 4 lay 18-fold (1.26 log units) below the measured number, outside the stated range (above it).
By their numbers in this assay, from the lowest: compound 2; then compounds 1 and 3 (each within the scatter of the next); then compound 4.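

In this assay, replacing 4-methylthiophen-2-yl with 4-formylthiophen-3-yl gives a 42-fold higher number from compound 2 to compound 4 (1.62 log units; beyond the scatter) on this aromatic carbon, ortho to a large group, so the read-out at this position proves highly sensitive even to a change that keeps a five-membered aromatic ring with one hetero atom. The entering group differs by only one more heavy atom, a double bond outside aromatic rings and one more hydrogen-bond acceptor, showing that a small change in these counts, together with a different ring attachment, can accompany a large loss of growth inhibition. Nothing among the available data accounts for this loss.

The step changes the point of attachment on the thiophene and the substituent together, so the compounds shown cannot separate the two changes, and a 4-methylthiophen-3-yl or a 4-formylthiophen-2-yl group at this position would be needed to tell them apart. On these data alone, it also remains open whether the formyl group itself matters, or whether a hydroxymethyl group, a carboxylic acid or an amine on the same thiophene would give a different number.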